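Allyl ester on the methoxy-bearing chain

The source may hold more compounds than are shown below. What is called first, only, known or untested is meant among the compounds shown, and "the series" means these compounds.

Three esters of the shared core have so far been run in a physicochemical assay for lipophilicity; on this read-out higher numbers stand for higher lipophilicity and lower numbers for lower lipophilicity. Compound 1 `COC(=O)/C=C(C)/C=C/CC(C)CCCC(C)C` gives 6.2 in this assay. Compound 2 `CC#CCOC(=O)/C=C(C)/C=C/CC(C)CCCC(C)C` gives 6.4, so that a number 0.20 log units higher from compound 1 to compound 2 (within the scatter). Compound 3 `COC(=O)/C=C(C)/C=C/CC(C)CCCC(C)(C)OC` gives 5, the lowest of the three numbers: a number 1.20 log units lower from compound 1 to compound 3 (beyond the scatter), and compound 2 lies further off still, beyond the scatter.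

Compound 4 `C=CCOC(=O)/C=C(C)/C=C/CC(C)CCCC(C)(C)OC` has not yet been measured in this assay. It differs from compound 3 in one place: vinyl in place of hydrogen on a saturated chain carbon bound to an oxygen next to a carbonyl group. Among the compounds with values here, only one measured step touches the same place, the exchange of hydrogen for prop-1-yn-1-yl on a saturated chain carbon bound to an oxygen next to a carbonyl group, and it was small: a number 0.20 log units higher from compound 1 to compound 2 (within the scatter), within the scatter. Within the data shown here, no step from the methoxy-bearing chain to an ester other than the methyl one is known, so the two parts are taken as independent.

On that basis compound 4 is expected to give a number somewhat higher than compound 3, probably at or just beyond the edge of the scatter: the estimate for compound 4 in this assay is 5.4, with a range from 5 to 5.9. This estimate corresponds to a number 0.40 log units higher from compound 3 to compound 4 (beyond the scatter).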

Compound 4, partition coefficient: 5.53
Beside the measured number, compound 4's estimate is 0.13 log units below it, and the stated range covers the measured number.
By their numbers in this assay, from the lowest: compound 3; then compound 4; then compounds 1 and 2 (each within the scatter of the next).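

On this assay, the change at the saturated chain carbon bound to an oxygen next to a carbonyl group now gives a step that clears the scatter: a number 0.53 log units higher from compound 3 to compound 4 (beyond the scatter). Within the data shown here, the only earlier step at this place, with prop-1-yn-1-yl entering on the chain without the methoxy group, stayed inside it: a number 0.20 log units higher from compound 1 to compound 2 (within the scatter). This position can therefore move the read-out measurably, and the methoxycarbonyl to allyloxycarbonyl change does so on the methoxy-bearing chain, although no measurement at hand accounts for the size of this step or for the contrast with the earlier one.

The two steps at this place differ both in the entering group and in the chain that carries it, so the compounds shown do not tell whether the contrast follows from vinyl versus prop-1-yn-1-yl or from the presence of the methoxy group. As far as these compounds go, how a carboxylic acid, or an ester with a longer chain such as butyl, would read on this assay at this place also remains open.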